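The source may hold more compounds than are shown below. What is called first, only, known or untested is meant among the compounds shown, and "the series" means these compounds.

Compound 2 `O=C(NO)c1ccc(NCc2nc(-c3ccc(C(F)(F)F)cc3)nn2-c2ccccc2)cc1` gives 41.6% in an assay on Sf9 cells for inhibition of protein deacetylase HDAC6 (Homo sapiens), read by fluorescence, with a stated time of 40 min, tested at 100 nM; a lower number here means less inhibition, a higher number more inhibition at the concentration tested (going by the name of the read-out); compound 1 `O=C(NO)c1ccc(NCc2nc(-c3cccc4cnccc34)nn2-c2ccccc2)cc1`, carrying isoquinolin-5-yl on the same aromatic carbon, gives 40.2%, so the two numbers sit within the scatter of each other. Compound 3 `CC(C)c1ccc(-c2nc(CNc3ccc(C(=O)NO)cc3)n(-c3ccccc3)n2)cc1` differs from compound 2 by isopropyl in place of trifluoromethyl on an aromatic carbon. Going by the values given here, the one measured step bearing on this position, a number 1.4 percentage points higher from compound 1 to compound 2 (within the scatter), shows that exchanging the whole aryl group left the read-out unchanged, and a change confined to the substituent on that aromatic carbon is expected to do no more. The expected step is a number 1.6 percentage points lower from compound 2 to compound 3 (within the scatter), within the scatter. Compound 3 is estimated at 40%, with a range from 26% to 54%.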

Compound 3, a percentage reported as inhibition, at one concentration (the size of the read-out at that concentration, not a potency): 27.6%
Beside the measured number, compound 3's estimate is 12.4 percentage points above it; the range from low to high includes it.
By their numbers in this assay, from the lowest: compound 3; then compounds 1 and 2 (each within the scatter of the next).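

In this assay, this position responds to a change of the substituent alone: a number 14 percentage points lower from compound 2 to compound 3 (beyond the scatter), with isopropyl in place of trifluoromethyl. The 4-isopropylphenyl group also separates from isoquinolin-5-yl, a number 12.6 percentage points lower from compound 1 to compound 3 (beyond the scatter), although the aryl groups of compound 1 and compound 2 showed no such separation. Nothing at hand accounts for these steps.

From the compounds shown here alone, it remains open whether the lower read-out is specific to isopropyl or extends to other groups on this aromatic carbon, such as a methoxy group, an amine or a carboxylic acid.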